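Swapping the Ester Side Chain of Compound 2

The compounds below may be only part of what the source reports. "The series", "measured", "known", "first", "only" and "open" are said of these compounds alone.

Of the compounds shown here, two sharing one core have been tested in a functional assay on DU-145 cells (Homo sapiens) for cytotoxicity, read by MTT assay; on this read-out lower numbers stand for stronger inhibition and higher numbers for weaker inhibition. Compound 1, `CC(C)=CC[C@@H](OC[C@@H](C)O)C1=CC(=O)c2c(O)ccc(O)c2C1=O`, gives 14300 nM. Compound 2, `CCCC(CC(=O)O[C@H](CC=C(C)C)C1=CC(=O)c2c(O)ccc(O)c2C1=O)OC(C)=O`, gives 55700 nM, the higher of the two numbers; its gap to compound 1 lies beyond the scatter, so compound 2 is the weaker of the pair. Compound 3, `CC[C@@](C)(O)CC(=O)O[C@H](CC=C(C)C)C1=CC(=O)c2c(O)ccc(O)c2C1=O`, has not yet been measured. It differs from compound 2 in one place: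

1-hydroxy-1-methylpropyl in place of 1-acetoxybutyl on a saturated chain carbon bound to a carbonyl carbon

Among the measured compounds shown here, no pair differing in a single place has been measured, so any expectation rests on the two values alone. Compound 3 is expected to sit somewhat lower than compound 2 because compound 1 gives 14300 nM while carrying a hydroxyl rather than an ester on its side chain. The expected step of a 1.9-fold lower number from compound 2 to compound 3 (0.27 log units; within the scatter) is modest, and a result within the scatter would not surprise. Compound 3 is therefore estimated at 30000 nM, between 10000 nM and 90000 nM.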

Compound 3, half-maximal inhibitory concentration: 12700 nM
Compound 3: the middle estimate sits 2.4-fold (0.37 log units) above what was measured, within the range that was stated.
By their numbers in this assay, from the lowest: compounds 3 and 1 (each within the scatter of the next); then compound 2.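

In this assay, among the compounds shown here, 1-hydroxy-1-methylpropyl in place of 1-acetoxybutyl on a saturated chain carbon bound to a carbonyl carbon gives the first single-place step (a 4.4-fold lower number from compound 2 to compound 3 (0.64 log units; beyond the scatter)), so the read-out responds to what this position carries. The ester link itself does not hold the number up: compound 3 keeps it and still cannot be told apart from compound 1 (a 1.1-fold lower number from compound 1 to compound 3 (0.05 log units; within the scatter)), which carries 2-hydroxypropyl on that oxygen instead. No measurement at hand accounts for the size of either step.

As far as these compounds go, whether the step follows the free hydroxyl or the branched 1-hydroxy-1-methylpropyl skeleton stays open, as the swap changes both at once and a 1-hydroxybutyl group at this place would separate them. From the compounds shown here alone, how an amine or a carboxylic acid would read there is also open.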